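The source may hold more compounds than are shown below. What is called first, only, known or untested is meant among the compounds shown, and "the series" means these compounds.

The series rests on a shared core carrying a chlorophenyl amide and an arylidene five-membered ring. Compound 1 `Cc1ccc(N2C(=O)C/C(=C\c3cccc(C(=O)Nc4ccc(Cl)cc4)c3)C2=O)cc1` bears a methyl on an aromatic carbon. In an ADME assay on NCM460 cells (Homo sapiens) for cytotoxicity, read by MTT assay, with a stated time of 72 h (on this read-out lower numbers stand for stronger inhibition and higher numbers for weaker inhibition), compound 1 gave only the limit of > 100000 nM. Compound 2 `O=C(Nc1ccc(Cl)cc1)c1cccc(/C=C2\CC(=O)N(c3ccccc3)C2=O)c1` has hydrogen in place of methyl on that aromatic carbon. In this assay compound 2 also gave only the limit of > 100000 nM. The step that the two limits leave unreadable from compound 1 to compound 2 therefore cannot be read, since both values sit at the limit of > 100000 nM in this assay, at which 2 of the 2 values shown sit, and compound 2 stands at the limit with no number of its own. Compound 3 `O=C(Nc1ccc(Cl)cc1)c1cccc(/C=C2\CC(=O)N(Cc3ccccc3)C2=O)c1` brings the next change: benzyl in place of phenyl on an amide-type nitrogen in a ring. Within the data shown here, no measured step bears on this change; the only step available, a step that the two limits leave unreadable from compound 1 to compound 2, is itself unreadable, so no size or direction can be drawn from it. The step that the limit leaves unreadable from compound 2 to compound 3 is thus expected to be none beyond the scatter, with the result most likely again reported only as a limit. Compound 3 is estimated in this assay at 150000 nM, with a range from 50000 nM to 500000 nM.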

Compound 3, half-maximal inhibitory concentration: > 100000 nM
Compound 3 ended at the assay's limit; the forecaster's own chance of this, stated with the estimate: 80%; the middle value is on the limit's open side.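

In this assay compound 3 gives > 100000 nM as a limit and not as a number. Among these compounds, no step among compound 1, compound 2 and compound 3 can be read: the limit of > 100000 nM in this assay, at which 3 of the 3 values shown sit. The compounds shown leave open how far each lies from that limit, and whether any change on the amide-type nitrogen in a ring alters the value at all.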